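The source may hold more compounds than are shown below. What is called first, only, known or untested is meant among the compounds shown, and "the series" means these compounds.

Values in a physicochemical assay for permeability, using PAMPA; a higher number here means that the compound crosses the layer faster, a lower number that the compound crosses the layer more slowly:

- compound 1 `Cc1cc(C)c(-c2nc(CN3CCC(C(=O)NCCCN4C[C@H](C)C[C@H](C)C4)CC3)c(C)o2)c(C)c1`: "not determined" (no result reported)
- compound 2 `Cc1ccccc1-c1nc(CN2CCC(C(=O)NCCCN3[C@H](C)CCC[C@@H]3C)CC2)c(C)o1`: 55.4 10^-6 cm/s
- compound 3 `CC[C@@H]1C[C@H](CC)CN(CCCNC(=O)C2CCN(Cc3nc(-c4c(F)cccc4F)oc3C)CC2)C1`: 130 10^-6 cm/s

Compound 1 has no single number in this assay, so it cannot be placed against compound 2 or compound 3 on the numbers shown. Among the measured compounds shown here, compound 2 gives 55.4 10^-6 cm/s and compound 3 gives 130 10^-6 cm/s in this assay; these two are separate compounds with several differences between them, and no step between measured compounds is available in this set.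

Compound 4 `Cc1ccc(-c2nc(CN3CCC(C(=O)NCCCN4C[C@H](C)C[C@H](C)C4)CC3)c(C)o2)cc1` differs from compound 1 in one place: 4-methylphenyl in place of 2,4,6-trimethylphenyl on an aromatic carbon. Without a measured starting value for compound 1 and without any measured step to lean on, the expected size of the change from compound 1 to compound 4 in this assay cannot be read from the data; a change within the usual scatter, in either direction, is as plausible as any.

The estimate for compound 4 therefore rests on compound 2 and compound 3 alone: in this assay compound 4 is expected to give about 75 10^-6 cm/s, in the range 30 10^-6 cm/s to 160 10^-6 cm/s.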

Compound 4, apparent permeability: 274 10^-6 cm/s
Estimate against measurement, compound 4: 3.7-fold (0.56 log units) below, outside the stated range (above it).
By their numbers in this assay, from the lowest: compound 2; then compound 3; then compound 4.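

In this assay, among the compounds shown here, compound 4 gives 274 10^-6 cm/s, but compound 1 has no single number, so no step from compound 1 to compound 4 can be read. The compounds shown leave open how 4-methylphenyl in place of 2,4,6-trimethylphenyl shifts the value in this assay. No measured evidence bears on this result.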